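The source may report more compounds than this note shows. Statements on the series, on what has been measured and on what is new or still open speak of the compounds shown alone.

Compound 1, `CC1(C)N=C(N)N=C(N)N1c1ccccc1N`, in an assay on isolated protein for inhibition of Dihydrofolate reductase (Mus musculus), at pH 7.20 (a higher number here means a more potent compound, by a factor of ten per unit of this negative logarithm, a lower number a less potent compound), gives 3.41.
Compound 2, `CCc1ccccc1N1C(N)=NC(N)=NC1(C)C`, in this assay gives 3.38.

Of these two numbers, compound 2 holds the lower one, though the gap to compound 1 is within the scatter. Among the measured compounds shown here, the one measured step, a number 0.03 log units lower from compound 1 to compound 2 (within the scatter), exchanged ethyl for amino on an aromatic carbon of the shared core and moved the number by no meaningful amount.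

Compound 3, `CC1(C)N=C(N)N=C(N)N1c1ccccc1I`, has not yet been measured. It differs from compound 2 in one place: iodo in place of ethyl on an aromatic carbon. For the measured compounds named here, only the step from compound 1 to compound 2 bears on this, and it showed that a change at this position barely moved the reading. Compound 3 is therefore expected to show no step beyond the scatter, a number 0.02 log units higher from compound 2 to compound 3 (within the scatter), in this assay. Compound 3 is estimated at 3.4, within a range from 2.9 to 3.9.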

Compound 3, logarithm of the reciprocal of the active concentration, log(1/C): 2.49
The estimate for compound 3 lay 0.91 log units above the measured number; the measured number lies below the stated range.
By their numbers in this assay, from the lowest: compound 3; then compounds 2 and 1 (each within the scatter of the next).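

In this assay, the position on the aromatic ring turns out not to be indifferent to what it carries: iodo in place of ethyl gives a number 0.89 log units lower from compound 2 to compound 3 (beyond the scatter), and iodo in place of amino gives a number 0.92 log units lower from compound 1 to compound 3 (beyond the scatter). Amino and ethyl had read alike here, so only this third group shows that a change at this place can move the number beyond the scatter, and it does so although iodo counts fewer heavy atoms than the ethyl it replaces. Nothing measured here accounts for the drop.

The compounds shown leave open whether the lower number belongs to iodo alone or is shared by chloro or bromo. They also leave open whether a methoxy group or a longer chain such as propyl would read with compound 1 and compound 2 or with compound 3.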